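Adding Chloro to a Chalcone Series Stuck at the Limit

The compounds below may be only part of what the source reports. "The series", "measured", "known", "first", "only" and "open" are said of these compounds alone.

Measured compounds:
compound 1, `Cc1nc(Nc2ccc(Cl)cc2)sc1C(=O)/C=C/c1ccccc1` — > 25000 nM
compound 2, `Cc1ccccc1Nc1nc(C)c(C(=O)/C=C/c2ccccc2)s1` — > 25000 nM
compound 3, `Cc1nc(Nc2ccccc2)sc1C(=O)/C=C/c1ccccc1` — > 25000 nM

In a functional assay on NCI-H460 cells (Homo sapiens) for cytotoxicity, read by MTT assay (on this read-out lower numbers stand for stronger inhibition and higher numbers for weaker inhibition), compound 1 gives > 25000 nM, which is a limit of the assay and not a number. Compound 2 gives > 25000 nM, likewise a limit. Compound 3 gives > 25000 nM, again a limit. All three values sit at the limit of > 25000 nM in this assay, at which 3 of the 3 values shown sit. As a result the three steps among them cannot be read: a step that the two limits leave unreadable from compound 1 to compound 2, a step that the two limits leave unreadable from compound 1 to compound 3 and a step that the two limits leave unreadable from compound 2 to compound 3. Compound 2 therefore stands nowhere in particular on the numbers shown; it shares the limit with the other two.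

Compound 4, `Cc1ccccc1Nc1nc(C)c(C(=O)/C=C/c2ccccc2Cl)s1`, differs from compound 2 by chloro in place of hydrogen on an aromatic carbon. Every measured step concerns the aryl group on the nitrogen, whereas this change, read one bond further out, is phenyl to 2-chlorophenyl on a different ring. Among the measured compounds shown here, no measured step bears on it, and none of the measured steps had a readable size. Since compound 2 gives only a limit, the most that can be expected is that compound 4 also returns a limit, with a step that the limit leaves unreadable from compound 2 to compound 4 that is itself expected to remain unreadable. Compound 4 is thus estimated at 30000 nM, in a range from 8000 nM to 100000 nM.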

Compound 4, half-maximal inhibitory concentration: > 25000 nM
Compound 4: no number, only a limit; the forecaster's own chance of this, stated with the estimate: 80%; the middle value is on the limit's open side.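

In this assay compound 4 gives > 25000 nM, a limit of the assay and not a number. Compound 2 also gives only a limit, so no step can be read between compound 2 and compound 4. The compounds shown leave open whether any change to them would bring a value off the limit: the limit of > 25000 nM in this assay, at which 4 of the 4 values shown sit.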